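The source may report more compounds than this note shows. Statements on the series, on what has been measured and on what is new or still open speak of the compounds shown alone.

Measured so far in a functional assay on THP-1 cells (Homo sapiens) for inhibition; on this read-out higher numbers stand for weaker inhibition and lower numbers for stronger inhibition:
- compound 1 `C[C@H](NC(=O)C(=O)Nc1ccccc1F)C(=O)N[C@@H](CC(=O)O)C(=O)COc1c(F)c(F)cc(F)c1F` gives 160 nM
- compound 2 `C[C@H](NC(=O)C(=O)Nc1cc(C(C)(C)C)ccc1C(C)(C)C)C(=O)N[C@@H](CC(=O)O)C(=O)COc1c(F)c(F)cc(F)c1F` gives 1840 nM
- compound 3 `C[C@H](NC(=O)C(=O)Nc1ccccc1-c1ccccc1)C(=O)N[C@@H](CC(=O)O)C(=O)COC(=O)c1c(F)c(F)cc(F)c1F` gives 500 nM

Compound 1 stands lowest of the three numbers in this assay, so it shows the strongest inhibition seen here. Its nearest neighbour is compound 3, whose higher number lies beyond the scatter; the furthest is compound 2, again beyond the scatter. Among the compounds with values here, both compound 2 and compound 3 carry larger substituents on the aniline ring than compound 1 and both give weaker inhibition, though compound 3 also differs elsewhere in the molecule, so no single-point step is isolated among the measured compounds.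

Compound 4 `C[C@H](NC(=O)C(=O)Nc1ccccc1Oc1ccccc1)C(=O)N[C@@H](CC(=O)O)C(=O)COc1c(F)c(F)cc(F)c1F` is not yet measured. It differs from compound 1 by phenoxy in place of fluoro on an aromatic carbon. With compound 2 at 1840 nM and compound 3 at 500 nM against compound 1 at 160 nM, an enlarged aniline substituent has so far gone with a higher number. For compound 4 the expected step is therefore a 2.8-fold higher number from compound 1 to compound 4 (0.45 log units; beyond the scatter), toward weaker inhibition and beyond the scatter, yet smaller than the gap to compound 2. Compound 4 is estimated at 450 nM, with a range from 150 nM to 1400 nM.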

Compound 4, half-maximal inhibitory concentration: 800 nM
Beside the measured number, compound 4's estimate is 1.8-fold (0.25 log units) below it; measured number inside the range.
By their numbers in this assay, from the lowest: compound 1; then compounds 3 and 4 (each within the scatter of the next); then compound 2.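

In this assay, within the data shown here, phenoxy in place of fluoro on an aromatic carbon gives a 5.0-fold higher number from compound 1 to compound 4 (0.70 log units; beyond the scatter), the first step that isolates a single change. At this position, a larger group carrying a ring and an ether oxygen therefore goes with weaker inhibition, although inhibition remains measurable. This one step cannot separate the contribution of the added ring from that of the oxygen, and no measurement in hand bears on the reason for the rise.

Still open, going by these compounds, is whether the step follows the ring, the oxygen or simply the number of added atoms at this carbon. Methoxy, which keeps the ether oxygen without the ring, and an unsubstituted hydrogen or an amine in the same place would each test a different part of that question.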